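Cytotoxicity notes on the imidazolylmethyl-aniline series

The compounds below may be only part of what the source reports. "The series", "measured", "known", "first", "only" and "open" are said of these compounds alone.

Measured so far:
compound 1 `c1ccc(-c2ccc(Cn3cncc3CNc3cccc(-c4ccccc4)c3)cc2)cc1`, 10000 nM
compound 2 `O=[N+]([O-])c1ccc(Cn2cncc2CNc2cccc(-c3ccccc3)c2)cc1`, 10000 nM
compound 3 `Cc1ccccc1-c1cc(NCc2cncn2Cc2ccc(-c3ccccc3)cc2)ccc1-c1nc2ccccc2s1`, > 1000 nM

In a toxicity assay on NIH3T3 cells (Mus musculus) for cytotoxicity, read by resazurin assay (on this read-out lower numbers stand for an effect already at smaller amounts and higher numbers for an effect only at larger amounts of compound), compound 1 gives 10000 nM and compound 2 gives 10000 nM. Compound 3 returns only a limit of the assay in this assay, > 1000 nM. Compound 1 therefore sits level with compound 2 at the digits shown; the remaining value is a limit, so no order among the three can be drawn beyond that.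

For the measured compounds named here, only one step between measured compounds is fully numbered: no change at the digits printed from compound 1 to compound 2 (within the scatter). Nitro in place of phenyl on an aromatic carbon leaves the read-out where it was, within the scatter. The limit for compound 3, (the limit of > 1000 nM in this assay, at which 1 of the 3 values shown sits), adds no number that would sharpen this picture.

Compound 4 `c1ccc(-c2ccc(Cn3cncc3CNc3ccc(-c4ccc[nH]4)c(-c4ccccc4)c3)cc2)cc1` is not yet measured in this assay. It differs from compound 1 by 1H-pyrrol-2-yl in place of hydrogen on an aromatic carbon, the new group entering ortho to a phenyl group and para to a large group on the shared core. Going by the values given here, the one measured step shows a change on the aromatic periphery without effect beyond the scatter, so for compound 4 no step beyond the scatter is expected: no change at the digits printed from compound 1 to compound 4 (within the scatter). The estimate for compound 4 in this assay is 10000 nM, with a range from 3000 nM to 30000 nM, and a fair chance that only a limit is reported.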

Compound 4, half-maximal effective concentration: > 10000 nM
Compound 4: a limit, no number; the forecaster's own chance of this, stated with the estimate: 40%; the middle value lies on the limit itself.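

Compared with the nitro for phenyl step, this change falls at a different place: 1H-pyrrol-2-yl enters on an aromatic carbon of a six-membered aromatic ring of carbon only, ortho to a phenyl group and para to a large group, and adds to the core of compound 1 instead of exchanging one group for another. The step reads a number no lower from compound 1 to compound 4 (the limit leaves the size open). In this assay compound 4 returns only a limit of the assay and not a number, and the size of the step therefore stays unknown: the limit of > 10000 nM in this assay, at which 1 of the 4 values shown sits.

What can be said for this position is thus one-sided: adding this five-membered aromatic ring, with its hydrogen-bond donor, does not bring the effect down to smaller amounts of compound. The compounds shown leave open whether a small amine or a carboxylic acid on the same carbon would keep the read-out in the same place, and whether 1H-pyrrol-2-yl would do so without the phenyl group ortho to it.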